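Swapping methyl for chloro on the benzyl ring

The compounds below may be only part of what the source reports. "The series", "measured", "known", "first", "only" and "open" are said of these compounds alone.

Three compounds share a core and differ in the group attached through a benzylic carbon to an oxygen on the aromatic ring. In an assay for inhibition of Amine oxidase [flavin-containing] B (Rattus norvegicus) (on this read-out lower numbers stand for stronger inhibition and higher numbers for weaker inhibition), compound 1 `N#CCCn1nc(-c2ccc(OCc3cccc(Cl)c3)cc2)oc1=O` gives 12 nM, compound 2 `COc1ccc(COc2ccc(-c3nn(CCC#N)c(=S)o3)cc2)cc1` gives 910 nM and compound 3 `Cc1cccc(COc2ccc(-c3nn(CCC#N)c(=S)o3)cc2)c1` gives 66 nM. Compound 3 thus stands second of the three, clearly weaker than compound 1 and clearly stronger than compound 2.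

Compound 4 `N#CCCn1nc(-c2ccc(OCc3cccc(Cl)c3)cc2)oc1=S` has not been measured in this assay. It differs from compound 3 by chloro in place of methyl on an aromatic carbon.

Going by the values given here, the only measured step that bears on this change is a 14-fold lower number from compound 2 to compound 3 (1.14 log units; beyond the scatter), showing that the substituent on the benzyl ring can matter a great deal. That step, however, moved a group to a different position, whereas here the position is kept and only the atom changes. Compound 1, which already carries the 3-chlorobenzyl group on a different core, gives 12 nM, which hints that chloro at this place is well tolerated. A modest gain, a 1.9-fold lower number from compound 3 to compound 4 (0.28 log units; within the scatter), is therefore expected, though a result within the scatter would not surprise. Compound 4 is estimated at 35 nM, with a likely range from 10 nM to 120 nM.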

Compound 4, half-maximal inhibitory concentration: 160 nM
Compound 4: middle estimate off by 4.6-fold (0.66 log units), on the low side; the measured number lies above the stated range.
By their numbers in this assay, from the lowest: compound 1; then compound 3; then compound 4; then compound 2.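

Replacing methyl with chloro at this place on the ring gives a 2.4-fold higher number from compound 3 to compound 4 (0.38 log units; beyond the scatter) in this assay, so the methyl group is the better of the two on this shared core, and the strong value of compound 1 with its 3-chlorobenzyl group does not carry over to compound 4, which differs from it only in the core. The 3-chlorobenzyl group still keeps much of the advantage over the 4-methoxybenzyl group, with a 5.7-fold lower number from compound 2 to compound 4 (0.75 log units; beyond the scatter), although this step changes both the substituent and its place on the ring. No measurement shown here offers an explanation for why chloro falls behind methyl on this core.

The compounds shown leave open whether methyl would also beat chloro on the core of compound 1, since that core appears here only with the chloro group. It also remains to be seen how other groups at this same place, such as trifluoromethyl, an amine or a longer chain like ethyl, would rank against methyl and chloro.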